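A few compounds are considered here, and "the series" means these few. Any claim that something is new, unique, unknown or untested is made for them only; others in the source may bear on it.

Measured so far:
compound 1 `COc1cccc(NC(=O)c2c(NO)cc(-c3ccccc3)oc2=O)c1` — in an ADME assay on Huh-7 cells (Homo sapiens) for cytotoxicity, with a stated time of 3 days (a higher number here means that more compound is tolerated, a lower number that less compound is tolerated), compound 1 gives > 20000 nM, a limit of the assay.
compound 2 `O=C(Nc1cccc(C(F)(F)F)c1)c1c(NO)cc(-c2ccccc2)oc1=O` — in this assay compound 2 gives 19000 nM.
compound 3 `Nc1ccccc1NC(=O)c1c(NO)cc(-c2ccccc2)oc1=O` — in this assay compound 3 gives > 20000 nM, a limit of the assay.

Compound 3 sits at the limit (the limit of > 20000 nM in this assay, at which 2 of the 3 values shown sit), so its position is known only as a bound. The measured steps are an at least 1.0-fold lower number from compound 1 to compound 2 (0.02 log units; that floor lies within the scatter), which lies within the scatter, and a step that the two limits leave unreadable from compound 1 to compound 3, which the two limits leave unreadable. Compound 4 `O=C(NC1CCCCC1)c1c(NO)cc(-c2ccccc2)oc1=O` differs from compound 3 by cyclohexyl in place of 2-aminophenyl on an amide-type nitrogen. Among the compounds with values here, no measured step carries a six-membered non-aromatic ring on the amide-type nitrogen, but every change at that nitrogen so far left the read-out at or near the limit. The step that the limit leaves unreadable from compound 3 to compound 4 is therefore expected to stay within the scatter, with a fair chance of another limit. Compound 4 is estimated at 22000 nM, range 9000 nM to 60000 nM.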

Compound 4, half-maximal cytotoxic concentration: 10500 nM
Beside the measured number, compound 4's estimate is 2.1-fold (0.32 log units) above it; low and high end bracket the measured number.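

Compound 4 puts the first non-aromatic ring on the amide-type nitrogen, and in this assay it reads as a number rather than a limit, giving an at least 1.9-fold lower number from compound 3 to compound 4 (0.27 log units; that floor lies within the scatter) and an at least 1.9-fold lower number from compound 1 to compound 4 (0.27 log units; that floor lies within the scatter). Both steps are only floors, and compounds 1 and 3 each stand at a limit: the limit of > 20000 nM in this assay, at which 2 of the 4 values shown sit.

Whether either true step exceeds the scatter cannot be read. Also open, on these data alone, is whether an open-chain alkyl group such as butyl, or a cyclohexyl ring carrying an amine, on that nitrogen would read like cyclohexyl.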